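Removing Bromo From Two Related Cores

The compounds below may be only part of what the source reports. "The series", "measured", "known", "first", "only" and "open" are said of these compounds alone.

Compound 1, `CNC(=O)c1cc(Oc2ccc(NC(=O)c3nn(-c4ccc(Br)cc4F)c(=O)cc3C)cc2F)ccn1`: 7930 nM
Compound 2, `CNC(=O)c1cc(Oc2ccc(NC(=O)c3nn(-c4ccccc4F)c(=O)cc3C)cc2F)ccn1`: > 40000 nM
Compound 3, `O=C(Nc1ccc(Oc2ncnc3ccsc23)c(F)c1)c1nn(-c2ccc(Br)cc2)ccc1=O`: 7840 nM

In a functional assay on A549 cells (Homo sapiens) for cytotoxicity, read by MTT assay, with a stated time of 72 h (on this read-out higher numbers stand for weaker inhibition and lower numbers for stronger inhibition), compound 1 gives 7930 nM. Compound 2 sits at the limit of > 40000 nM in this assay, at which 1 of the 3 values shown sits, a limit rather than a number. The step of an at least 5.0-fold higher number from compound 1 to compound 2 (0.70 log units; beyond the scatter) goes with hydrogen in place of bromo on an aromatic carbon. Compound 3 gives 7840 nM in this assay; the difference between the cores of compound 1 and compound 3 is not broken down here. Compound 4, `O=C(Nc1ccc(Oc2ncnc3ccsc23)c(F)c1)c1nn(-c2ccccc2)ccc1=O`, differs from compound 3 by hydrogen in place of bromo on an aromatic carbon, the same kind of change as before, though in compound 1 the place is also meta to a fluoro group and in compound 3 it is not. Resting on an at least 5.0-fold higher number from compound 1 to compound 2 (0.70 log units; beyond the scatter), a step of a 5.1-fold higher number from compound 3 to compound 4 (0.71 log units; beyond the scatter) is expected. Compound 4 is therefore estimated at 40000 nM, with a fair chance that only a limit is reported.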

Compound 4, half-maximal inhibitory concentration: 19700 nM
For compound 4 the middle estimate is 2.0-fold (0.31 log units) above the measured one; the measured number falls inside the stated range.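

In this assay, going from 4-bromophenyl to phenyl goes with a 2.5-fold higher number from compound 3 to compound 4 (0.40 log units; beyond the scatter), the same direction as the change gave on the core of compound 1. Whether the step keeps its size from one core to the other is not settled: the same change on two cores in this assay, an at least 5.0-fold higher number (0.70 log units; beyond the scatter) from compound 1 to compound 2 and a 2.5-fold higher number (0.40 log units; beyond the scatter) from compound 3 to compound 4; the limit leaves it open whether they differ. Compound 2 carries a limit, > 40000 nM, not a number.

The compounds shown have only bromo or hydrogen at this place, so it stays open whether another group there, such as chloro, methoxy or an amine, would give matching steps on both cores. From the compounds shown here alone, it also stays open whether the step from bromo to hydrogen would point the same way on a third core.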